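The source may hold more compounds than are shown below. What is called first, only, known or untested is meant among the compounds shown, and "the series" means these compounds.

Series notes. Compound 1 `Cc1noc(-c2cc3ccccc3[nH]2)n1` is the parent; compound 2 `COc1ccc2[nH]c(-c3nc(C)no3)cc2c1` carries the same core with a methoxy, the change being (methoxy in place of hydrogen on an aromatic carbon). In a functional assay on COLO 320 cells (Homo sapiens) for antiproliferative activity, read by WST assay, with a stated time of 72 h (a higher number here means a weaker inhibitor, a lower number a stronger inhibitor), compound 1 gives 11800 nM, and compound 2 gives 10400 nM; the step of a 1.1-fold lower number from compound 1 to compound 2 (0.05 log units; within the scatter) is a small one. Compound 3 `COc1ccc(-c2noc(-c3cc4ccccc4[nH]3)n2)cc1` has a different core; how it differs from the core of compound 1 is not broken down here. In this assay compound 3 gives 27700 nM, the highest of the three numbers. Compound 4 `COc1ccc(-c2noc(-c3cc4cc(OC)ccc4[nH]3)n2)cc1` is unmeasured; it differs from compound 3 by methoxy in place of hydrogen on an aromatic carbon, the same change as from compound 1 to compound 2. The step is expected to be a 1.1-fold lower number from compound 3 to compound 4 (0.04 log units; within the scatter), small like the earlier one, because a 1.1-fold lower number from compound 1 to compound 2 (0.05 log units; within the scatter) stayed within the scatter. Compound 4 is therefore estimated at 25000 nM, between 12000 nM and 55000 nM.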

Compound 4, half-maximal inhibitory concentration: 28300 nM
Estimate against measurement, compound 4: 1.1-fold (0.05 log units) below; the measured number falls inside the stated range.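

In this assay, methoxy in place of hydrogen on an aromatic carbon gives a 1.0-fold higher number from compound 3 to compound 4 (0.01 log units; within the scatter), and the two cores agree on this change: the same change on two cores in this assay, a 1.1-fold lower number (0.05 log units; within the scatter) from compound 1 to compound 2 and a 1.0-fold higher number (0.01 log units; within the scatter) from compound 3 to compound 4, 1.2-fold (0.06 log units) apart, within the scatter of two such steps. The change therefore stays small on both the core of compound 1 and the core of compound 3, but this does not show that it would stay small on other cores or in other assays. Going by these compounds alone, the one step here that goes beyond the scatter is a different change, 4-methoxyphenyl in place of methyl on an aromatic carbon, which gives a 2.7-fold higher number from compound 2 to compound 4 (0.43 log units; beyond the scatter) and is seen only once.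

The compounds shown leave open whether a different group at the methoxy place, such as an amine, a carboxylic acid or a longer alkoxy chain, would move the number beyond the scatter. As far as these compounds go, whether methoxy behaves the same elsewhere on that six-membered ring also remains open.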